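This account rests on a few compounds, and the source may have more. Where it says the series, first, only, none or still open, it means among the compounds named here.

Three close relatives of one shared core have been measured in an assay on cells for activation of Guanylate cyclase soluble subunit alpha-1 (Rattus norvegicus), read by cGMP accumulation and immunoassay, with a stated time of 10 min; a lower number here means that less compound is needed, a higher number that more compound is needed for the effect. Compound 1 `COC(=O)N(CCO)c1c(N)nc(-c2nn(Cc3ccccc3F)c3ncccc23)nc1N` gives 0.3 uM. Compound 2 `COC(=O)Nc1c(N)nc(-c2nn(Cc3ccccc3F)c3ncccc23)nc1N`, which carries hydrogen in place of 2-hydroxyethyl on an amide-type nitrogen, gives 0.3 uM, and the step is no change at the digits printed from compound 1 to compound 2 (within the scatter). Compound 3 `Nc1nc(-c2nn(Cc3ccccc3F)c3ncccc23)nc(N)c1NC(=O)OCC1CC1` gives 0.2 uM. Its number is the smallest of the three, but only by a 1.5-fold lower number from compound 1 to compound 3 (0.18 log units; within the scatter) and by a 1.5-fold lower number from compound 2 to compound 3 (0.18 log units; within the scatter), so the three compounds cannot be told apart on these numbers.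

Compound 4 `Nc1nc(-c2nn(Cc3ccccc3F)c3ncccc23)nc(N)c1N1C[C@H](C(F)(F)F)OC1=O` is the next compound. Relative to compound 3, the change is a group of 10 heavy atoms (4 carbon, 1 nitrogen, 2 oxygen, 3 fluorine; one five-membered non-aromatic ring with 2 hetero atoms) in place of a group of 8 heavy atoms (5 carbon, 1 nitrogen, 2 oxygen; one three-membered non-aromatic ring of carbon only), on an aromatic carbon. All three measured steps touch the same aromatic carbon, and each of them, whether the chain on the amide-type nitrogen was removed or a cyclopropyl was added on the chain bound to oxygen, stayed within the scatter. For the measured compounds named here, the new change is larger than any of those, since the whole open group is exchanged for a ring and the single hydrogen-bond donor is lost, and no measured step tests such an exchange. On the evidence available the expectation for compound 4 is a step of a 1.5-fold higher number from compound 3 to compound 4 (0.18 log units; within the scatter), that is, no movement beyond the scatter, with a wider range of doubt than the measured steps suggest. The value expected for compound 4 is 0.3 uM, between 0.1 uM and 1 uM.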

Compound 4, minimum effective concentration: 0.2 uM
Compound 4: the middle estimate sits 1.5-fold (0.18 log units) above what was measured; low and high end bracket the measured number.
By their numbers in this assay, from the lowest: compounds 3, 4, 1 and 2 (each within the scatter of the next).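

In this assay, exchanging the open group on this aromatic carbon, ortho to two amino groups, for a five-membered non-aromatic ring with 2 hetero atoms, a defined stereocentre and a trifluoromethyl group gives no change at the digits printed from compound 3 to compound 4 (within the scatter). Set against the two other open groups, the ring gives a 1.5-fold lower number from compound 2 to compound 4 (0.18 log units; within the scatter) and a 1.5-fold lower number from compound 1 to compound 4 (0.18 log units; within the scatter), so this position accepts a ring as well as an open chain, and compound 4 shows that the amide hydrogen found in compound 3 is not needed for a value in this range. Nothing available here bears on why so large an exchange leaves the number within the scatter.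

The compounds shown leave open what the trifluoromethyl group and the defined stereocentre each contribute, which the same ring with a hydrogen in place of trifluoromethyl, or with the opposite arrangement at the stereocentre, could separate. They also leave open whether any group on this aromatic carbon can move the number beyond the scatter, for example a simple amine or a carboxylic acid.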